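Ethoxy for methyl on a quinoline-like carboxylic acid amide

This account rests on a few compounds, and the source may have more. Where it says the series, first, only, none or still open, it means among the compounds named here.

Two closely related anilides have been examined in a functional assay on A-375 cells (Homo sapiens) for antiproliferative activity, read by MTT assay, with a stated time of 24 h, tested at 0.02 ug/mL; on this read-out higher numbers stand for a stronger effect at the one concentration tested and lower numbers for a weaker effect. Compound 1 `Cc1ccc2nc(C(=O)Nc3c(F)cc(-c4cccc(F)c4)cc3F)c(C)c(O)c2c1` carries a hydroxy group on its fused core and gives 0.38% in this assay. Compound 2 `Cc1ccc2nc(C(=O)Nc3c(F)cc(-c4cccc(F)c4)cc3F)c(C)c(C(=O)O)c2c1` differs only in that a carboxy replaces that hydroxy, and in this assay compound 2 gives 0.02%. Among the measured compounds shown here, the single measured step, a number 0.4 percentage points lower from compound 1 to compound 2 (within the scatter), is within the scatter, so the two compounds cannot be ordered; compound 2 simply holds the lower of the two numbers, with compound 1 lying within the scatter of it.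

Compound 3 `CCOc1ccc2nc(C(=O)Nc3c(F)cc(-c4cccc(F)c4)cc3F)c(C)c(C(=O)O)c2c1` is the next member and has not been measured. It differs from compound 2 by ethoxy in place of methyl on an aromatic carbon. For the measured compounds named here, no measured step touches this change: the only step available concerns the carboxy and hydroxy groups, not the methyl, and it was within the scatter. Going by the values given here, with both measured numbers sitting close to zero and no step of any size in hand, the expected step of a number 0.2 percentage points higher from compound 2 to compound 3 (within the scatter) is none beyond the scatter. Compound 3 is therefore estimated to give 0.2% in this assay, within a range from 0% to 8%.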

Compound 3, a percentage reported as inhibition, at one concentration (the size of the read-out at that concentration, not a potency): 1.02%
Beside the measured number, compound 3's estimate is 0.8 percentage points below it; the range from low to high includes it.
By their numbers in this assay, from the lowest: compounds 2, 1 and 3 (each within the scatter of the next).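

Ethoxy in place of methyl on an aromatic carbon, para to a fused ring and meta to a fused ring, is the first change at this position among the compounds shown, and in this assay it gives a number 1 percentage points higher from compound 2 to compound 3 (within the scatter) on the shared core that keeps the carboxy group. Enlarging this substituent from the single carbon of methyl to the three heavy atoms of ethoxy, and adding one hydrogen-bond acceptor, therefore moves the read-out by no more than the usual scatter, so this one pair shows no effect of the change at the single concentration tested. Nothing in the data at hand speaks to a cause for this result.

The compounds shown leave open whether a longer chain such as butoxy, an amine or a chlorine atom at this position would give a step beyond the scatter. They also leave open whether ethoxy would behave in the same way on the core of compound 1, where a hydroxy group stands in place of the carboxy group.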